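The source may report more compounds than this note shows. Statements on the series, on what has been measured and on what is new or still open speak of the compounds shown alone.

Compound 3 `Brc1ccc(-c2cn3ccnc3c(-c3ccc4ncn(C5CCCCC5)c4c3)n2)cc1` gives 35.5% in a functional assay on NCI-H522 cells (Homo sapiens) for inhibition, read by sulforhodamine B assay, with a stated time of 48 h, tested at 10 uM (on this read-out lower numbers stand for less inhibition and higher numbers for more inhibition at the one concentration tested (going by the name of the read-out)), the highest of the three numbers: compound 1 `O=Cc1ccc(-c2cn3ccnc3c(-c3ccc4ncn(C5CCCCC5)c4c3)n2)cc1` gives 25.3% and compound 2 `c1ccc2c(-c3cn4ccnc4c(-c4ccc5ncn(C6CCCCC6)c5c4)n3)cccc2c1` gives 19.3%, so that a number 10.2 percentage points higher from compound 1 to compound 3 (beyond the scatter) and a number 16.2 percentage points higher from compound 2 to compound 3 (beyond the scatter). Compound 4 `Fc1ccccc1-c1cn2ccnc2c(-c2ccc3ncn(C4CCCCC4)c3c2)n1` differs from compound 3 by 2-fluorophenyl in place of 4-bromophenyl on an aromatic carbon. Going by the values given here, no measured step exchanges one halogen for another or shifts a substituent around the phenyl ring; the two steps into compound 3 show only that varying the aryl group on the shared core moves the read-out by modest amounts, and that the two compounds lacking 4-bromophenyl both sit lower. A modest downward step a number 10.5 percentage points lower from compound 3 to compound 4 (beyond the scatter) is therefore expected. Compound 4 is estimated at 25%, with a range from 12% to 38%.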

Compound 4, a percentage reported as inhibition, at one concentration (the size of the read-out at that concentration, not a potency): 17.8%
Compound 4: middle estimate off by 7.2 percentage points, on the high side; the measured number falls inside the stated range.
By their numbers in this assay, from the lowest: compounds 4, 2 and 1 (each within the scatter of the next); then compound 3.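

In this assay, 2-fluorophenyl in place of 4-bromophenyl at this position gives a number 17.7 percentage points lower from compound 3 to compound 4 (beyond the scatter) and leaves compound 3 alone at the top of the series. The other two steps stay within the scatter, a number 1.5 percentage points lower from compound 2 to compound 4 (within the scatter) and a number 7.5 percentage points lower from compound 1 to compound 4 (within the scatter), so 2-fluorophenyl cannot be told apart from naphthalen-1-yl or 4-formylphenyl here. No measurement available here accounts for the step. This change alters the halogen and its place on the phenyl ring together, and the compounds shown do not separate the two. As far as these compounds go, how an amine or a carboxylic acid on that ring would read also stays open.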